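Three compounds at the assay limit; one more to come

The source may report more compounds than this note shows. Statements on the series, on what has been measured and on what is new or still open speak of the compounds shown alone.

Measured so far in an ADME assay on WI-38 cells (Homo sapiens) for antiproliferative activity, read by MTT assay, with a stated time of 72 h; on this read-out lower numbers stand for stronger inhibition and higher numbers for weaker inhibition:
- Compound 1, `CCCCCCC#Cc1c(CCCCCC)oc2nc(=O)n(Cc3cn(-c4ccc(Cl)cc4)nn3)cc12`: compound 1 gives > 100000 nM, a limit of the assay.
- Compound 2, `O=c1nc2oc(C3CC3)cc2cn1Cc1cn(-c2ccc(Cl)cc2)nn1`: compound 2 gives > 100000 nM, again a limit.
- Compound 3, `CCCCCc1ccc(C#Cc2c(-c3ccc(CCCCC)cc3)oc3nc(=O)n(Cc4cn(-c5ccc(Cl)cc5)nn4)cc23)cc1`: compound 3 gives > 100000 nM, also a limit.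

Among the compounds with values here, compound 2 therefore stands where every value so far stands, as noted in the limit of > 100000 nM in this assay, at which 3 of the 3 values shown sit; no number separates it from compound 1 or compound 3. Compound 4, `O=c1nc2oc(CCCCl)cc2cn1Cc1cn(-c2ccc(Cl)cc2)nn1`, differs from compound 2 only by 3-chloropropyl in place of cyclopropyl on an aromatic carbon. Within the data shown here, no step between measured compounds is available to gauge this change, so no shift beyond the scatter is expected in this assay. Compound 4 is expected to remain at the limit, with an estimated 200000 nM (range 100000 nM to 1000000 nM), a step that the limit leaves unreadable from compound 2 to compound 4 that is estimated rather than measured.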

Compound 4, half-maximal inhibitory concentration: 72500 nM
The estimate for compound 4 lay 2.8-fold (0.44 log units) above the measured number; the whole stated range lies above it.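

In this assay, 3-chloropropyl in place of cyclopropyl on an aromatic carbon next to the ring oxygen gives an at least 1.3-fold lower number from compound 2 to compound 4 (0.13 log units; that floor lies within the scatter). Within the data shown here, compound 4 is thus the first compound with a readable number, so this position can carry a group that brings the read-out inside the assay range. The true size of the step stays unknown, and it may be no more than scatter, because compound 2 sits at a limit: the limit of > 100000 nM in this assay, at which 3 of the 4 values shown sit.

Whether the chlorine or the open chain accounts for the number remains open, and a plain propyl group at this position would separate the two. An amine or a longer chain here is also untested in the compounds shown.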